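Replacing 4-fluorobenzyl with butyl on the shared core

The source may hold more compounds than are shown below. What is called first, only, known or untested is meant among the compounds shown, and "the series" means these compounds.

Compound 1 `CCOC(=O)N1[C@@H]2C=C[C@@](OC)(C(=O)c3c2cc(OC)c(OC)c3OCc2ccc(F)cc2)N1C(=O)OCC`: 51.8 ug/mL
Compound 2 `COc1cc2c(c(OCc3ccccc3)c1OC)C(=O)[C@]1(OC)C=C[C@H]2N(C(=O)OCC(C)C)N1C(=O)OCC(C)C`: 94 ug/mL

Both compounds were tested in an ADME assay on KB cells (Homo sapiens) for cytotoxicity; on this read-out lower numbers stand for an effect already at smaller amounts and higher numbers for an effect only at larger amounts of compound. Among the measured compounds shown here, compound 1, at 51.8 ug/mL, stands within the usual scatter of compound 2, the only other compound measured so far, so the two values cannot be told apart.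

Compound 3 `CCCCOc1c(OC)c(OC)cc2c1C(=O)[C@]1(OC)C=C[C@H]2N(C(=O)OCC)N1C(=O)OCC` has not yet been measured. It departs from compound 1 by propyl in place of 4-fluorophenyl on a saturated chain carbon bound to an oxygen on an aromatic ring, which puts propyl in place of 4-fluorophenyl on a saturated chain carbon bound to an oxygen on an aromatic ring. The same difference reads as (4-fluorobenzyl)oxy to butoxy.

For the measured compounds named here, no measured step shows what this change does, so no step beyond the scatter is expected. The expected change a 1.2-fold higher number from compound 1 to compound 3 (0.06 log units; within the scatter) is small. Compound 3 is estimated at 60 ug/mL, with an expected range from 25 ug/mL to 130 ug/mL.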

Compound 3, concentration for half-maximal effect: 76 ug/mL
Estimate against measurement, compound 3: 1.3-fold (0.10 log units) below, and the stated range covers the measured number.
By their numbers in this assay, from the lowest: compounds 1, 3 and 2 (each within the scatter of the next).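

Among the compounds shown here, compound 3 gives the first reading of this position in this assay and of this change, propyl in place of 4-fluorophenyl on a saturated chain carbon bound to an oxygen on an aromatic ring (a 1.5-fold higher number from compound 1 to compound 3 (0.17 log units; within the scatter)). The change removes both the aromatic ring and the fluorine from this place, yet the two compounds cannot be told apart, so in this pair neither loss is seen to shift the number beyond the scatter. No measurement at hand offers a reason for this outcome.

From the compounds shown here alone, it remains open whether an amine or a carboxylic acid at the end of this chain, or a chain longer than butyl, would move the number beyond the scatter. A single pair also cannot say whether the same change reads alike when other groups on the shared core differ.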